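The source may report more compounds than this note shows. Statements on the series, on what has been measured and on what is new or still open speak of the compounds shown alone.

Compound 1 (`CSc1ncnc2c1c(-c1ccsc1)cn2[C@@H]1O[C@H](CO)[C@@H](O)[C@H]1O`) gives > 20000 nM in a functional assay on CEM-DNR-bulk cells (Homo sapiens), read by MTT assay, with a stated time of 72 h (a lower number here means a stronger inhibitor, a higher number a weaker inhibitor), and this is a limit, not a number. Compound 2 (`CSc1ncnc2c1c(-c1ccccc1)cn2[C@@H]1O[C@H](CO)[C@@H](O)[C@H]1O`) gives > 20000 nM, also a limit. Compound 3 (`C#Cc1cn([C@@H]2O[C@H](CO)[C@@H](O)[C@H]2O)c2ncnc(SC)c12`) gives 110 nM in this assay. Compound 1 therefore sits at the limit of > 20000 nM in this assay, at which 2 of the 3 values shown sit.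

Compound 4 (`Cc1ncnc2c1c(-c1ccsc1)cn2[C@@H]1O[C@H](CO)[C@@H](O)[C@H]1O`) keeps the thiophen-3-yl group of compound 1 and differs elsewhere: methyl in place of methylsulfanyl on an aromatic carbon. For the measured compounds named here, no measured step changes that group, so the evidence is indirect. The measured steps all exchange thiophen-3-yl, phenyl or ethynyl on another aromatic carbon. Of these, a step that the two limits leave unreadable from compound 1 to compound 2 gives no size, while an at least 180-fold lower number from compound 1 to compound 3 (2.25 log units; beyond the scatter) and an at least 180-fold lower number from compound 2 to compound 3 (2.25 log units; beyond the scatter) are large and both lead to ethynyl. Compound 4 carries no ethynyl, so a gain of that size is not expected, and no step beyond the scatter is expected in this assay. The step expected from the estimate is an at least 1.3-fold lower number from compound 1 to compound 4 (0.12 log units; that floor lies within the scatter). For compound 4 the estimated value is 15000 nM, with an expected range from 3000 nM to 30000 nM.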

Compound 4, half-maximal inhibitory concentration: 8560 nM
The estimate for compound 4 lay 1.8-fold (0.24 log units) above the measured number; low and high end bracket the measured number.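

In this assay, methyl in place of methylsulfanyl gives an at least 2.3-fold lower number from compound 1 to compound 4 (0.36 log units; beyond the scatter). For the compounds shown here, this is the first readable step at the position opposite the ring nitrogen, and it shows that the number moves with the thiophen-3-yl group unchanged, whereas the earlier readable steps all exchanged that group for ethynyl. The size of the step is only a floor, because compound 1 stands at a limit: the limit of > 20000 nM in this assay, at which 2 of the 4 values shown sit.

On these data alone, it remains open whether methyl in place of methylsulfanyl would give a comparable step on compound 3, which carries ethynyl, or on compound 2, which carries phenyl. Also open, as far as these compounds go, is how an amine, a methoxy group or a longer chain would read at this position in this assay.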